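A few compounds are considered here, and "the series" means these few. Any claim that something is new, unique, unknown or untested is made for them only; others in the source may bear on it.

Working notes on a short series of aryl-substituted ketones and the related tertiary alcohol.

Compound 1 `Cc1cccc(N(C)CC2CCC/C(=C\c3ccccc3)C2=O)c1` is the reference ketone. In a functional assay on the whole organism (strain Kunming) for inhibition, with Mus musculus as the target, in the writhing test, with stated times of 1 h and 15 min, at a dose of 200 mg/kg by the oral route (a lower number here means less inhibition, a higher number more inhibition at the dose given (going by the name of the read-out)), compound 1 gives 76.7%. Compound 2 `Cc1ccc(/C=C2\CCCC(CN(C)c3cccc(C)c3)C2=O)cc1` carries the change methyl in place of hydrogen on an aromatic carbon on the core of compound 1; in this assay compound 2 gives 75.8%. The step of a number 0.9 percentage points lower from compound 1 to compound 2 (within the scatter) is therefore flat, and the two values are not distinguished.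

Compound 3 `COc1ccc(C2(O)/C(=C/c3ccccc3)CCCC2CN(C)c2ccccc2)cc1` belongs to a second core; how it differs from compound 1 is not broken down here. In this assay compound 3 gives 75.7%, a number within the scatter of both compound 1 and compound 2, so the three measured compounds are not ordered by this read-out.

Compound 4 `COc1ccc(C2(O)/C(=C/c3ccccc3)CCCC2CN(C)c2ccc(C)cc2)cc1` is the not yet measured partner of compound 3. It carries the change (methyl in place of hydrogen on an aromatic carbon). The place is the same as in the step from compound 1 to compound 2, although cut one bond further out the change on the core of compound 3 reads methyl(phenyl)amino to methyl(4-methylphenyl)amino, so the methyl enters a different phenyl than in compound 2. Among the compounds with values here, because the only measured instance of this change, a number 0.9 percentage points lower from compound 1 to compound 2 (within the scatter), lies within the scatter, the expected step from compound 3 to compound 4 is likewise small, estimated at a number 0.7 percentage points lower from compound 3 to compound 4 (within the scatter). For compound 4 the estimate in this assay is 75%, with an expected range from 66% to 83%.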

Compound 4, a percentage reported as inhibition, in the whole organism at one dose (the size of the read-out at that dose, not a potency): 78.7%
Estimate against measurement, compound 4: 3.7 percentage points below; the measured number falls inside the stated range.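

On the core of compound 3, methyl in place of hydrogen on an aromatic carbon gives, in this assay, a number 3 percentage points higher from compound 3 to compound 4 (within the scatter), so compound 4 is not separated from compound 3 by this read-out. Set beside the earlier step, the two instances of this change do not differ, and both are flat: the same change on two cores in this assay, a number 0.9 percentage points lower (within the scatter) from compound 1 to compound 2 and a number 3 percentage points higher (within the scatter) from compound 3 to compound 4, 3.9 percentage points apart, within the scatter of two such steps. Within the data shown here, this fits a change that carries across the two cores without a detectable shift, but it shows only that no step is seen in either case; there is no measurable effect to transfer, the methyl enters a different phenyl on each core, and a read-out at a single dose says nothing about potency.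

The compounds shown leave open whether any substituent at this place can move the read-out beyond the scatter, for instance chlorine, a carboxylic acid or a longer chain in place of the methyl in the 4-methylphenyl group. They also leave open how the methyl behaves when it enters the same phenyl on both cores, and whether the two cores would stay indistinguishable at doses other than the one used here.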